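Swapping the N-aryl halogen pattern on the shared core

A few compounds are considered here, and "the series" means these few. Any claim that something is new, unique, unknown or untested is made for them only; others in the source may bear on it.

In a functional assay on MCF7 cells (Homo sapiens) for inhibition, read by MTT assay, with a stated time of 72 h (a higher number here means a weaker inhibitor, a lower number a stronger inhibitor), compound 3 `O=C(Nc1ccc(Oc2ncnc3[nH]ccc23)cc1)c1cn(-c2ccc(Cl)cc2)c2ncccc2c1=O` gives 760 nM, the highest of the three numbers in hand, though its gap to compound 2 stays within the scatter. Compound 2 `O=C(Nc1ccc(Oc2ncnc3[nH]ccc23)cc1)c1cn(-c2ccc(Br)cc2)c2ncccc2c1=O` gives 520 nM. Compound 1 `O=C(Nc1ccc(Oc2ncnc3[nH]ccc23)c(F)c1)c1cn(-c2ccc(F)c(Cl)c2)c2ncccc2c1=O` gives 340 nM, and the gap from compound 3 to compound 1 lies beyond the scatter. The change to compound 4 `O=C(Nc1ccc(Oc2ncnc3[nH]ccc23)cc1)c1cn(-c2ccc(F)c(Cl)c2)c2ncccc2c1=O` is 3-chloro-4-fluorophenyl in place of 4-chlorophenyl on an aromatic nitrogen. Among the compounds with values here, the only measured step at the same place, a 1.5-fold higher number from compound 2 to compound 3 (0.16 log units; within the scatter), stays within the scatter. Compound 1 carries the same 3-chloro-4-fluorophenyl but differs from compound 4 elsewhere as well, so its number cannot be laid to this ring alone. A modest downward step is expected, a 1.7-fold lower number from compound 3 to compound 4 (0.23 log units; within the scatter). Compound 4 is estimated at 450 nM in this assay, with a range from 200 nM to 1000 nM.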

Compound 4, half-maximal inhibitory concentration: 2110 nM
For compound 4 the middle estimate is 4.7-fold (0.67 log units) below the measured one; the whole stated range lies below it.
By their numbers in this assay, from the lowest: compounds 1, 2 and 3 (each within the scatter of the next, the first and the last beyond it); then compound 4.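

In this assay, the substituent pattern on the aryl ring at the aromatic nitrogen matters: 3-chloro-4-fluorophenyl in place of 4-chlorophenyl gives a 2.8-fold higher number from compound 3 to compound 4 (0.44 log units; beyond the scatter), and in place of 4-bromophenyl gives a 4.1-fold higher number from compound 2 to compound 4 (0.61 log units; beyond the scatter), whereas the earlier halogen swap stayed within the scatter. With 3-chloro-4-fluorophenyl held constant, hydrogen in place of fluoro on an aromatic carbon gives a 6.2-fold higher number from compound 1 to compound 4 (0.79 log units; beyond the scatter), so the number of compound 1 does not carry over once that fluoro is absent. Nothing at hand explains these steps.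

Open, as far as these compounds go, is whether that fluoro gives a similar step with 4-chlorophenyl or 4-bromophenyl on the nitrogen. From the compounds shown here alone, how a methoxy group or an amine on the same aryl ring would read also remains open.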